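Second Acetoxy Group on a Series Seen Only at the Limit

The compounds below may be only part of what the source reports. "The series", "measured", "known", "first", "only" and "open" are said of these compounds alone.

Compound 3 `CC(=O)Oc1cccc2cc(-c3ccccc3)c(=O)oc12` is known in an assay on CHO cells for displacement of a labelled ligand from adenosine receptor A2b (Homo sapiens), read by radioligand binding (a higher number here means a weaker inhibitor, a lower number a stronger inhibitor), only as a limit: compound 3 gives > 30000 nM, a limit of the assay and not a number. Compound 1 `CCOc1cccc2cc(-c3ccccc3)c(=O)oc12` gives > 30000 nM, likewise a limit. Compound 2 `COc1ccc(-c2cc3cccc(OC)c3oc2=O)cc1` gives > 30000 nM, again a limit. Going by the values given here, the single measured step, a step that the two limits leave unreadable from compound 1 to compound 3, is therefore unreadable, and the limit of > 30000 nM in this assay, at which 3 of the 3 values shown sit, is all the series shows so far. Compound 4 `CC(=O)Oc1ccc2cc(-c3ccccc3)c(=O)oc2c1OC(C)=O` differs from compound 3 by acetoxy in place of hydrogen on an aromatic carbon. Among the compounds with values here, no measured step bears on adding a second acetoxy group, so neither size nor direction can be read from the data. Compound 4 is expected to stay at the limit, with an estimated 30000 nM (range 10000 nM to 100000 nM). The estimated step of a number no higher from compound 3 to compound 4 (the limit leaves the size open) is expected to be none beyond the scatter.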

Compound 4, inhibition constant: > 30000 nM
Compound 4: only a limit was reported (the forecaster's own chance of this, stated with the estimate: 85%); the middle value sits exactly at the limit.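

The step between compound 3 and compound 4 cannot be read, as both results are limits of the assay and not numbers in this assay: the limit of > 30000 nM in this assay, at which 4 of the 4 values shown sit.

Still open, as far as these compounds go, is whether any change to the shared core gives a readable value in this assay.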